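Swapping the Aryl Group on an Amide Carbonyl

The compounds below may be only part of what the source reports. "The series", "measured", "known", "first", "only" and "open" are said of these compounds alone.

Of the compounds shown here, three have so far been tested in a functional assay on HEK293 cells for agonist activity at D(4) dopamine receptor (Homo sapiens), read by FLIPR; on this read-out higher numbers stand for an effect only at larger amounts of compound and lower numbers for an effect already at smaller amounts. Compound 1 `Cc1cccc(NC(=O)CN2CCC(c3ccc(O)cc3)CC2)c1` gives 70 nM in this assay. Compound 2 `Cc1cc(C(=O)NCN2CCC(c3cccc[n+]3[O-])CC2)ccc1F` gives 50 nM. Compound 3 `CSc1cccc(NC(=O)CN2CCC(c3cccc[n+]3[O-])CC2)c1` gives 100 nM. Of these three numbers, that of compound 2 is the lowest, yet its gaps to compound 1 and to compound 3 both lie within the usual scatter of repeated measurements, so no real order can be read from them.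

Compound 4 `Cc1cc(C)cc(C(=O)NCN2CCC(c3cccc[n+]3[O-])CC2)c1` has not yet been measured. It differs from compound 2 in one place: 3,5-dimethylphenyl in place of 4-fluoro-3-methylphenyl on a carbonyl carbon. Going by the values given here, no pair of measured compounds differs in exactly this way, so there is no measured step of this kind to draw on. The rest of the molecule is kept, and the change exchanges one six-membered aromatic ring of carbon only for another. The expected step from compound 2 to compound 4 is therefore small, a 1.2-fold higher number from compound 2 to compound 4 (0.08 log units; within the scatter), in no direction beyond the scatter. Compound 4 is estimated at 60 nM, with a range from 20 nM to 180 nM.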

Compound 4, half-maximal effective concentration: 90 nM
For compound 4 the middle estimate is 1.5-fold (0.18 log units) below the measured one; low and high end bracket the measured number.
By their numbers in this assay, from the lowest: compounds 2, 1, 4 and 3 (each within the scatter of the next).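

Going by these compounds alone, this is the first measured step at this place, on a carbonyl carbon whose other neighbour is an amide-type nitrogen: in this assay, 3,5-dimethylphenyl in place of 4-fluoro-3-methylphenyl gives a 1.8-fold higher number from compound 2 to compound 4 (0.26 log units; within the scatter). The aryl group can therefore lose its fluorine and carry a second methyl group without a difference that this read-out can separate from repeat-to-repeat noise, at least for this one pair on this shared core. Nothing measured here offers an explanation for how close the two compounds lie.

Still open, on these data alone, is whether this place accepts something other than a substituted phenyl ring, such as an aryl group carrying an amine or a carboxylic acid, or a longer alkyl chain. As far as these compounds go, it is also open whether the same swap would give a similarly small step on a different core, since a single pair cannot show how general it is.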